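Swapping a butyl for cyclopropyl on an inactive core

The compounds below may be only part of what the source reports. "The series", "measured", "known", "first", "only" and "open" are said of these compounds alone.

Of the compounds shown here, three have been tested in a functional assay for inhibition, with Homo sapiens as the target; on this read-out higher numbers stand for weaker inhibition and lower numbers for stronger inhibition. Compound 1 `CCCCc1nnc(O)n2c(CCC)nc(C)c12` reaches only the assay limit, > 48000 nM. Compound 2 `Cc1ncn2c(NCc3ccco3)nncc12` likewise gives only a limit, > 48000 nM. Compound 3 `CSc1nnc(-c2ccccc2)c2c(C)nc(C(C)C)n12` also stops at a limit, > 48000 nM. Compound 1 therefore stands at the limit of > 48000 nM in this assay, at which 3 of the 3 values shown sit, and no number separates it from its two companions. Compound 4 `CCCc1nc(C)c2c(C3CC3)nnc(O)n12` differs from compound 1 by cyclopropyl in place of butyl on an aromatic carbon. Going by the values given here, no measured pair shows what such a swap does here, so no direction can be read off for the step. The expectation is that compound 4 again gives no number, with an estimated step from compound 1 to compound 4 of a step that the limit leaves unreadable from compound 1 to compound 4. Compound 4 is expected near 60000 nM, in a range from 20000 nM to 200000 nM.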

Compound 4, half-maximal inhibitory concentration: > 48000 nM
Compound 4 gave a limit, no number; the forecaster's own chance of this, stated with the estimate: 85%; the middle value does not contradict the limit.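

Compound 1 and compound 4 both give only a limit, so swapping butyl for cyclopropyl yields no readable step. The compounds shown leave open whether any change to the shared core would give an actual number in this assay.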